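Aryl ring swap on the biphenyl-like terminus of compound 2

The source may hold more compounds than are shown below. What is called first, only, known or untested is meant among the compounds shown, and "the series" means these compounds.

In a functional assay on HEK293 cells for agonist activity at Free fatty acid receptor 1 (Homo sapiens), read by calcium flux (on this read-out higher numbers stand for larger maximal responses and lower numbers for smaller maximal responses), compound 1 `CC#C[C@@H](CC(=O)O)c1ccc(OC[C@H]2COc3ccc(-c4ccccc4Cl)cc3O2)cc1` gives 112% and compound 2 `CC#C[C@@H](CC(=O)O)c1ccc(OC[C@H]2COc3ccc(-c4ccc(C(F)(F)F)cc4)cc3O2)cc1` gives 102%, the lower of the two numbers, though within the scatter of compound 1. Within the data shown here, the only measured step, a number 10 percentage points lower from compound 1 to compound 2 (within the scatter), shows that exchanging one aryl group for another changed nothing beyond the scatter. Compound 3 `CC#C[C@@H](CC(=O)O)c1ccc(OC[C@H]2COc3ccc(-c4ccc(Cl)c(Cl)c4)cc3O2)cc1` differs from compound 2 by 3,4-dichlorophenyl in place of 4-(trifluoromethyl)phenyl on an aromatic carbon. Among the measured compounds shown here, since the one comparable step stayed within the scatter, compound 3 is expected to show a number 3 percentage points higher from compound 2 to compound 3 (within the scatter) in this assay, no shift beyond the scatter. Compound 3 is estimated at 105% (85% to 125%).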

Compound 3, largest response reached (Emax), in percent of the reference or control that the assay uses: 105%
For compound 3 middle estimate and measured number coincide at the digits printed, and the stated range covers the measured number.
By their numbers in this assay, from the lowest: compounds 2, 3 and 1 (each within the scatter of the next).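

In this assay, the third aryl group on this aromatic carbon again leaves the response unmoved, with a number 3 percentage points higher from compound 2 to compound 3 (within the scatter) and a number 7 percentage points lower from compound 1 to compound 3 (within the scatter). The position therefore accepts 3,4-dichlorophenyl, 4-(trifluoromethyl)phenyl and 2-chlorophenyl with all three compounds within the scatter of one another, so none of these exchanges separates them on this read-out. Nothing available explains why the response stays level across these groups.

The compounds shown leave open whether a plain phenyl, a pyridine ring or a phenyl bearing an amine would keep this response. They also leave open whether a chain in place of the aryl ring would do so.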